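Half-life when a nitrile gives way to trifluoromethyl

The source may hold more compounds than are shown below. What is called first, only, known or untested is meant among the compounds shown, and "the series" means these compounds.

compound 1 `Cc1cc(CCC(=O)O)ccc1-c1noc(-c2ccc(OC(C)C)c(C#N)c2)n1` gives 0.7 h
compound 2 `Cc1cc([C@H]2C[C@H]2C(=O)O)ccc1-c1noc(-c2ccc(OC(C)C)c(C#N)c2)n1` gives 7.4 h
compound 3 `Cc1cc([C@@H]2C[C@H]2C(=O)O)ccc1-c1noc(-c2ccc(OC(C)C)c(C#N)c2)n1` gives 4.9 h; 5.9 h (2 entries)

All three numbers come from an in vivo ADME assay on the whole organism (strain Sprague-Dawley) for metabolic stability, with Rattus norvegicus as the target (on this read-out lower numbers stand for a shorter-lived compound and higher numbers for a longer-lived compound), and compound 1, at 0.7 h on that scale, holds the lowest of them. Its nearest neighbour is still far off, with an 11-fold higher number from compound 1 to compound 2 (1.02 log units; beyond the scatter) in a step that puts 2-carboxycyclopropyl in place of 2-carboxyethyl on an aromatic carbon.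

Compound 4 `Cc1cc(CCC(=O)O)ccc1-c1noc(-c2ccc(OC(C)C)c(C(F)(F)F)c2)n1` keeps the 2-carboxyethyl group of compound 1 and changes a different place trifluoromethyl in place of cyano on an aromatic carbon with trifluoromethyl in place of cyano on an aromatic carbon, ortho to an isopropoxy group. For the measured compounds named here, no measured step makes this swap. The large step above concerns the other group, so its size does not carry over. Neither the fact that compounds 2 and 3 differ only in the configuration as drawn nor the several entries of compound 3 in this assay, 4.9 h; 5.9 h (2 entries) touches the cyano group either.

The expectation therefore starts from compound 1 at 0.7 h and no step beyond the scatter is expected in this assay in either direction. The estimated change is a 1.3-fold higher number from compound 1 to compound 4 (0.11 log units; within the scatter) and stays within the scatter. Compound 4 is expected at about 0.9 h with 0.4 h to 2 h as the estimated range.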

Compound 4, half-life: 1.1 h
Compound 4: middle estimate off by 1.2-fold (0.09 log units), on the low side, and the stated range covers the measured number.
By their numbers in this assay, from the lowest: compounds 1 and 4 (each within the scatter of the next); then compound 2.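

For the compounds shown here, this is the first look at the place ortho to an isopropoxy group, where cyano, counted as a hydrogen-bond acceptor, gives way to trifluoromethyl, which is not. In this assay the swap amounts to a 1.6-fold higher number from compound 1 to compound 4 (0.20 log units; within the scatter) and so does not separate the two groups, at least with the 2-carboxyethyl group held fixed. The change that does show up beyond the scatter lies at the other place in the molecule, where the chain is altered, and it is of another size: an 11-fold higher number from compound 1 to compound 2 (1.02 log units; beyond the scatter) and nothing like it appears at this position. What is on hand concerns the cyclopropyl compounds and offers no explanation for how closely the nitrile and trifluoromethyl compounds read.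

Trifluoromethyl appears here only with the 2-carboxyethyl chain, so it remains open whether the same swap would read alike on a compound carrying the 2-carboxycyclopropyl group. As far as these compounds go, it is also open how a different group at this place, such as a single chlorine atom or an amide, would fare on the same half-life scale.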